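Terminal ring exchange at the far end of the chain

This account rests on a few compounds, and the source may have more. Where it says the series, first, only, none or still open, it means among the compounds named here.

Measured so far:
compound 1 `COc1cc(N)c(Cl)cc1C(=O)NC1CCN(CCCCCCCCN2C(=O)c3ccccc3C2=O)CC1` gives 3.16 nM in a functional assay on HEK293 cells for agonist activity at 5-hydroxytryptamine receptor 4 (Homo sapiens), read by cAMP accumulation; a higher number here means that more compound is needed for the effect, a lower number that less compound is needed
compound 2 `COc1cc(N)c(Cl)cc1C(=O)NC1CCN(CCCCCCCCN2CCCCC2)CC1` gives 3.16 nM

For the measured compounds named here, compound 2 stands level with compound 1; the one step measured, no change at the digits printed from compound 1 to compound 2 (within the scatter), replaced a much larger terminal group with a smaller ring at the same chain end and produced nothing beyond the scatter.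

Compound 3 `COc1cc(N)c(Cl)cc1C(=O)NC1CCN(CCCCCCCCN2CCN(S(C)(=O)=O)CC2)CC1` is the next variation at that position: 4-(methylsulfonyl)piperazin-1-yl in place of piperidin-1-yl on a saturated chain carbon, eight bonds along the chain from an amine nitrogen in a ring. Going by the values given here, the single step that bears on it is the one already described, which left the read-out flat despite a far bigger change in size and ring type than the present one. Among the compounds with values here, with only that flat step to draw on, no movement beyond the scatter is expected in this assay, and the step is estimated as a 1.1-fold higher number from compound 2 to compound 3 (0.04 log units; within the scatter).

Compound 3 is therefore expected to give about 3.5 nM, with a range from 1.2 nM to 12 nM.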

Compound 3, half-maximal effective concentration: 39.8 nM
The estimate for compound 3 lay 11-fold (1.06 log units) below the measured number; the measured number lies above the stated range.
By their numbers in this assay, from the lowest: compounds 1 and 2 (each within the scatter of the next); then compound 3.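

The terminal position is not indifferent to the group it carries in this assay: 4-(methylsulfonyl)piperazin-1-yl in place of piperidin-1-yl gives a clear loss (a 13-fold higher number from compound 2 to compound 3 (1.10 log units; beyond the scatter)), so the earlier flat step does not hold for every terminal ring. The same group also stands apart from the terminal group of compound 1 (a 13-fold higher number from compound 1 to compound 3 (1.10 log units; beyond the scatter)), and size alone does not follow the read-out, since compound 1 carries the largest group yet stands level with compound 2, which carries the smallest. No supporting data bear on the origin of this step.

As far as these compounds go, whether the step belongs to the methylsulfonyl group or to the piperazine ring stays open; plain piperazin-1-yl, 4-acetylpiperazin-1-yl or morpholin-4-yl at this chain end would separate the two. From the compounds shown here alone, whether the step persists with a shorter chain is also open.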